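This account rests on a few compounds, and the source may have more. Where it says the series, first, only, none or still open, it means among the compounds named here.

Compound 1 `Cc1ccc(C(=O)Nc2sc3c(c2C(N)=O)CCN(Cc2c(Cl)cccc2Cl)C3)cc1`: 47400 nM
Compound 2 `Cc1ccc(C(=O)Nc2sc3c(c2C(N)=O)CCN(Cc2ccc(Cl)cc2Cl)C3)cc1`: > 50000 nM

Both compounds were tested in a functional assay on HeLa cells (Homo sapiens) for antiproliferative activity, with a stated time of 24 h; a higher number here means a weaker inhibitor, a lower number a stronger inhibitor. Compound 2 stands at a limit of this assay and has no exact number: > 50000 nM. Compound 3 `NC(=O)c1c(NC(=O)c2ccccc2F)sc2c1CCN(Cc1ccc(Cl)cc1Cl)C2` differs from compound 2 in one place: 2-fluorophenyl in place of 4-methylphenyl on a carbonyl carbon. In words, 2-fluorophenyl stands in place of 4-methylphenyl on a carbonyl carbon.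

For the measured compounds named here, no measured step changes this group. Going by the values given here, the only measured step, an at least 1.0-fold higher number from compound 1 to compound 2 (0.02 log units; that floor lies within the scatter), concerns a different group and lies within the scatter, so it offers no direct guide to the size or direction of this change. Among the compounds with values here, the value of compound 1, 47400 nM, gives the only exact number in this small set, so the expectation stays close to it, with no step beyond the scatter. The estimated change is an at least 1.2-fold lower number from compound 2 to compound 3 (0.09 log units; that floor lies within the scatter). Compound 3 is expected at about 40000 nM, with an estimated range of 10000 nM to 80000 nM.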

Compound 3, half-maximal inhibitory concentration: 27500 nM
For compound 3 the middle estimate is 1.5-fold (0.16 log units) above the measured one, within the range that was stated.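

In this assay compound 3 gives 27500 nM as an exact number, so this place on the carbonyl carbon now has a real reading with 2-fluorophenyl. Compound 2 stands at > 50000 nM which is a limit and not a number. The step is an at least 1.8-fold lower number from compound 2 to compound 3 (0.25 log units; that floor lies within the scatter) and only its floor is known, so the swap from 4-methylphenyl to 2-fluorophenyl may be small or much larger, because one end of the pair is a limit: the limit of > 50000 nM in this assay, at which 1 of the 3 values shown sits.

From the compounds shown here alone, whether a plain phenyl or a pyridyl on the same carbonyl carbon would read differently stays open. Also open, going by these compounds, is whether 2-fluorophenyl would give a similar number alongside the 2,6-dichlorophenyl of compound 1 rather than the 2,4-dichlorophenyl of compound 3.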